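One Fluorine Less in a Weakly Antiproliferative Series

The compounds below may be only part of what the source reports. "The series", "measured", "known", "first", "only" and "open" are said of these compounds alone.

The measured compounds are few. Compound 1, `O=C(N/N=C/c1ccccc1O)c1ccc(-c2ccc(F)cc2)o1`, gives only a limit of > 40000 nM in a functional assay on KB cells (Homo sapiens) for antiproliferative activity, read by sulforhodamine B assay, with a stated time of 48 h; a lower number here means a stronger inhibitor, a higher number a weaker inhibitor. Compound 2, `O=C(N/N=C/c1ccc(-c2ccc(F)cc2F)o1)c1ccccc1O`, gives 55300 nM in this assay. Compound 3, `O=C(N/N=C/c1ccccc1O)c1ccc(-c2ccc(F)cc2F)o1`, gives only a limit of > 40000 nM in this assay.

Among the compounds with values here, compound 2 therefore stands as the single real number among the three values; the other two sit at the limit described by the limit of > 40000 nM in this assay, at which 2 of the 3 values shown sit. Compound 4, `O=C(N/N=C/c1ccc(-c2ccc(F)cc2)o1)c1ccccc1O`, is not yet measured. It differs from compound 2 by hydrogen in place of fluoro on an aromatic carbon. Within the data shown here, the only measured step of this kind, a step that the two limits leave unreadable from compound 1 to compound 3, runs the opposite way, fluoro in place of hydrogen, and its size cannot be read from two limits. Among the measured compounds shown here, no measured step thus fixes a size for the change from compound 2 to compound 4, and nothing among the three compounds points to a shift beyond the scatter in either direction. Compound 4 is expected to give 55000 nM, between 25000 nM and 120000 nM. The expected step is a 1.0-fold lower number from compound 2 to compound 4 (0.00 log units; within the scatter), that is, no change beyond the scatter, with a real chance that only a limit is returned.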

Compound 4, half-maximal inhibitory concentration: 39000 nM
For compound 4 the middle estimate is 1.4-fold (0.15 log units) above the measured one; low and high end bracket the measured number.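

Within the data shown here, replacing 2,4-difluorophenyl with 4-fluorophenyl gives the first step that can be read in this assay: hydrogen in place of fluoro on this aromatic carbon, ortho to a large group, gives a 1.4-fold lower number from compound 2 to compound 4 (0.15 log units; within the scatter). In this one pair with two real numbers, the fluoro at this position therefore makes no difference beyond the scatter. The pair remains a single readable comparison in a series with little measured range: the limit of > 40000 nM in this assay, at which 2 of the 4 values shown sit.

On these data alone, whether chloro, methoxy or an amine at this position would move the number beyond the scatter remains open. Also open, as far as these compounds go, is whether a carboxylic acid in place of the fluoro that remains in compound 4 would give a stronger or a weaker inhibitor.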